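Chloro to isopropyl on two cores in cell growth inhibition

The source may hold more compounds than are shown below. What is called first, only, known or untested is meant among the compounds shown, and "the series" means these compounds.

Measured so far:
Compound 1 `CCOC(=O)c1noc2c1CN(C(=O)c1cc(Cl)c(O)cc1O)CC2` in a functional assay on NCI-H460 cells (Homo sapiens) for inhibition, read by sulforhodamine B assay, with a stated time of 72 h (a higher number here means a weaker inhibitor, a lower number a stronger inhibitor), gives > 20000 nM, which is a limit of the assay.
Compound 2 `CCOC(=O)c1noc2c1CN(C(=O)c1cc(C(C)C)c(O)cc1O)CC2` in this assay gives 870 nM.
Compound 3 `CCNC(=O)c1noc2c1CN(C(=O)Nc1cc(Cl)c(O)cc1O)CC2` in this assay gives > 1000 nM, which is a limit of the assay.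

Among the measured compounds shown here, the one measured step is an at least 22-fold lower number from compound 1 to compound 2 (1.36 log units; beyond the scatter), made by isopropyl in place of chloro on an aromatic carbon; since compound 1 sits at the limit of > 20000 nM in this assay, at which 1 of the 3 values shown sits, the step is only a lower bound. Compound 4 `CCNC(=O)c1noc2c1CN(C(=O)Nc1cc(C(C)C)c(O)cc1O)CC2` differs from compound 3 by isopropyl in place of chloro on an aromatic carbon, the same change at the same place. The difference between the two cores of compound 1 and compound 3 is not broken down here. On these data alone, compound 3 sits at the limit of > 1000 nM in this assay, at which 1 of the 3 values shown sits, so its own number is unknown.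

For compound 4 a step that the limit leaves unreadable from compound 3 to compound 4 in this assay is expected, resting on the step of an at least 22-fold lower number from compound 1 to compound 2 (1.36 log units; beyond the scatter) seen on the other core. Compound 4 is estimated at 1500 nM, expected between 300 nM and 8000 nM.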

Compound 4, half-maximal inhibitory concentration: > 1000 nM
Compound 4: only a limit was reported (the forecaster's own chance of this, stated with the estimate: 25%); the middle value lies beyond the limit too.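

No step can be read from compound 3 to compound 4, as both values are limits of the assay: the limit of > 1000 nM in this assay, at which 2 of the 4 values shown sit.

On these data alone, whether isopropyl in place of chloro changes the number on the core of compound 3 stays open.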